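Sulfonyl-quinoxaline anilines: methoxy to chloro on the aniline

A few compounds are considered here, and "the series" means these few. Any claim that something is new, unique, unknown or untested is made for them only; others in the source may bear on it.

Compound 1 `COc1ccc(Nc2nc3ccccc3nc2S(=O)(=O)c2ccccc2)cc1` carries a methoxy group on its aniline ring. In a functional assay on KB cells (Homo sapiens) for cytotoxicity, read by MTT assay, with a stated time of 72 h (a lower number here means a stronger inhibitor, a higher number a weaker inhibitor), compound 1 gives "not determined" (no result reported), so no number is available for it. Compound 2 `COc1cc(Nc2nc3ccccc3nc2S(=O)(=O)c2ccccc2)cc(OC)c1`, with two methoxy groups on the same ring, is likewise without a result: in this assay compound 2 gives "not determined" (no result reported). Within the data shown here, the only measured member of the series is compound 3 `Nc1cccc(Nc2nc3ccccc3nc2S(=O)(=O)c2ccccc2)c1`, which has an amino group in place of the methoxy substitution; in this assay compound 3 gives 4290 nM. Compound 1 therefore cannot be placed among the numbers shown; the single anchor is compound 3.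

Compound 4 `O=S(=O)(c1ccccc1)c1nc2ccccc2nc1Nc1ccc(Cl)cc1` is related to compound 1 by a single change: chloro in place of methoxy on an aromatic carbon. Among the measured compounds shown here, no step between measured compounds exists for this change, and with compound 1 unmeasured the size of the step in this assay cannot be read from the data; any difference is expected to be modest, in either direction, and quite possibly within the scatter. Taking compound 3 as the only reference, compound 4 is expected to give about 3500 nM in this assay, estimated within 800 nM to 15000 nM.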

Compound 4, half-maximal inhibitory concentration: 41200 nM
Beside the measured number, compound 4's estimate is 12-fold (1.07 log units) below it; the measured number lies above the stated range.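

In this assay the aniline ring now has a second number, and the substituent clearly matters: a 9.6-fold higher number from compound 3 to compound 4 (0.98 log units; beyond the scatter), with 4-chlorophenyl in place of 3-aminophenyl on the nitrogen. That step changes both the group and its place on the ring, so it cannot separate the two, and the methoxy to chloro step itself cannot be read with compound 1 lacking a number. No supporting measurement bears on why the number rises.

Going by these compounds, it remains open whether an amine on the aromatic carbon that holds the chloro in compound 4, para to a large group, would bring the number back towards that of compound 3. A carboxylic acid or a longer alkoxy chain at that carbon is also left open by the compounds shown.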